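Replacing the piperidine with a pyridine in a solubility series

The source may hold more compounds than are shown below. What is called first, only, known or untested is meant among the compounds shown, and "the series" means these compounds.

The study measured two compounds in a physicochemical assay for solubility, read by spectrophotometry, in phosphate buffer, with a stated time of 2 h, at pH 7.4 (on this read-out lower numbers stand for lower solubility and higher numbers for higher solubility), and leaves a third open. Compound 1 `COc1ccc2[nH]c(C(=O)N3CC(=O)N(Cc4ccccc4)[C@@H](CN4CCCCC4)C3)cc2c1` carries a piperidin-1-yl group on the saturated chain carbon. In this assay compound 1 gives > 25000 nM, which is a limit of the assay and not a number. Compound 2 `O=C(c1cc2cc(C3CC3)ccc2[nH]1)N1CC(=O)N(Cc2ccccc2)[C@@H](CN2CCC(F)CC2)C1` is a different pairing of the same core; in this assay compound 2 gives 12400 nM. Of compound 1 one can say only where it sits: the limit of > 25000 nM in this assay, at which 1 of the 2 values shown sits.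

Compound 3 `COc1ccc2[nH]c(C(=O)N3CC(=O)N(Cc4ccccc4)[C@@H](Cc4ccccn4)C3)cc2c1` is the unmeasured member. It differs from compound 1 in one place (pyridin-2-yl in place of piperidin-1-yl on a saturated chain carbon bound to a saturated ring carbon). Among the measured compounds shown here, no measured step of this kind exists in the data, so the size of the step can only be estimated. The study expects compound 3 to give 8000 nM in this assay, with a range from 2500 nM to 26000 nM. That estimate means a step from compound 1 to compound 3 of an at least 3.1-fold lower number from compound 1 to compound 3 (0.49 log units; beyond the scatter), expected to be downward and beyond the scatter, though the limit for compound 1 leaves its true size open.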

Compound 3, solubility: > 100000 nM
Compound 3: no number, only a limit; the forecaster's own chance of this, stated with the estimate: 15%; at least 12-fold (1.09 log units) between middle value and limit.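

Among the compounds shown here, no step from compound 1 to compound 3 can be read, as the results for both are limits of the assay and not numbers. In this assay compound 3 gives the limit > 100000 nM. In this assay compound 1 gives the limit > 25000 nM. The compounds shown leave open what true size, and even what direction, the change from piperidin-1-yl to pyridin-2-yl has on this read-out.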